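Swapping azepan-1-yl for anilino on a sulfonyl sulfur

The source may report more compounds than this note shows. Statements on the series, on what has been measured and on what is new or still open speak of the compounds shown alone.

Measured so far in a toxicity assay on Vero cells (Chlorocebus sabaeus) for cytotoxicity, read by MTT assay; a higher number here means a weaker inhibitor, a lower number a stronger inhibitor:
- compound 1 `CCOC(=O)NC(=O)c1ccsc1NC(=O)c1ccc(S(=O)(=O)N2CCC2)cc1`: > 64 ug/mL (a limit, not a number)
- compound 2 `CCOC(=O)NC(=O)c1ccsc1NC(=O)c1ccc(S(=O)(=O)N2CCCCC2)cc1`: 18.6 ug/mL
- compound 3 `CCOC(=O)NC(=O)c1ccsc1NC(=O)c1ccc(S(=O)(=O)N2CCCCCC2)cc1`: 3.42 ug/mL

Compound 1 gives only a limit (> 64 ug/mL) and no exact number. Compound 3 has the lowest value of the three (3.42 ug/mL) and so the strongest effect on the cells, with compound 2 the nearest to it.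

Compound 4 `CCOC(=O)NC(=O)c1ccsc1NC(=O)c1ccc(S(=O)(=O)Nc2ccccc2)cc1` has anilino in place of azepan-1-yl on a sulfonyl sulfur. Going by the values given here, three measured steps bear on this change, all at that same sulfur: an at least 3.4-fold lower number from compound 1 to compound 2 (0.53 log units; beyond the scatter), then a 5.4-fold lower number from compound 2 to compound 3 (0.74 log units; beyond the scatter), and over the whole ring series an at least 18-fold lower number from compound 1 to compound 3 (1.27 log units; beyond the scatter) in total. These steps show that changes at this place can move the number a great deal. However, each of them swaps one non-aromatic ring for another, so they guide the new change only loosely.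

Compound 3 already sits at the low end of the set, and the other values lie higher, so a rise is more likely than a further fall. The expected change is a 2.6-fold higher number from compound 3 to compound 4 (0.42 log units; beyond the scatter) as a modest step, with wide uncertainty. The estimated value for compound 4 is 9 ug/mL with an expected range from 2.5 ug/mL to 35 ug/mL until it is measured.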

Compound 4, half-maximal inhibitory concentration: 14.5 ug/mL
Estimate against measurement, compound 4: 1.6-fold (0.21 log units) below; measured number inside the range.
By their numbers in this assay, from the lowest: compound 3; then compounds 4 and 2 (each within the scatter of the next). At a limit, above all of these: compound 1.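

Anilino enters with the same number of heavy atoms as azepan-1-yl, yet in this assay the swap gives a 4.2-fold higher number from compound 3 to compound 4 (0.63 log units; beyond the scatter), so the low number of compound 3 does not carry over when the group on the sulfonyl sulfur changes in kind at constant size. Up to now only non-aromatic rings had stood at this place, and the aromatic ring of anilino, which also brings a hydrogen-bond donor that azepan-1-yl lacks, gives a result that cannot be told apart from that of piperidin-1-yl: a 1.3-fold lower number from compound 2 to compound 4 (0.11 log units; within the scatter). The third step, an at least 4.4-fold lower number from compound 1 to compound 4 (0.64 log units; beyond the scatter), starts from a limit and not a number: the limit of > 64 ug/mL in this assay, at which 1 of the 4 values shown sits.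

This swap changes two things at once, a non-aromatic ring for an aromatic one and no donor for a hydrogen-bond donor, and the compounds shown do not tell which of the two goes with the rise in the number. A cyclohexylamino group, which keeps the nitrogen hydrogen without the aromatic ring, and a methyl(phenyl)amino group, which keeps the aromatic ring without that hydrogen, would separate them at this same sulfur.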